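The source may hold more compounds than are shown below. What is called first, only, known or untested is meant among the compounds shown, and "the series" means these compounds.

Three compounds share one core and differ only in the aryl group on a double-bonded chain carbon bound to an aromatic carbon. In a functional assay on K562 cells (Homo sapiens) for cytotoxicity, read by CCK-8 assay, with a stated time of 72 h (on this read-out higher numbers stand for weaker inhibition and lower numbers for stronger inhibition), compound 1 `C=CCn1c(=O)/c(=C\c2cccc(Cl)c2)[nH]c(=O)/c1=C\c1ccccc1OC` gives 2700 nM. Compound 2 `C=CCn1c(=O)/c(=C\c2cccc(F)c2)[nH]c(=O)/c1=C\c1ccccc1OC` gives 4100 nM in this assay. Compound 3 `C=CCn1c(=O)/c(=C\c2ccccc2OC)[nH]c(=O)/c1=C\c1ccccc1OC` gives 7400 nM in this assay, the highest of the three numbers. The step of a 2.7-fold higher number from compound 1 to compound 3 (0.44 log units; beyond the scatter) lies beyond the scatter, whereas the step of a 1.8-fold higher number from compound 2 to compound 3 (0.26 log units; within the scatter) and the step of a 1.5-fold higher number from compound 1 to compound 2 (0.18 log units; within the scatter) both stay within it.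

Compound 4 `C=CCn1c(=O)/c(=C\c2cccc(Br)c2)[nH]c(=O)/c1=C\c1ccccc1OC` has not yet been measured in this assay. Relative to compound 3 the change is 3-bromophenyl in place of 2-methoxyphenyl on a double-bonded chain carbon bound to an aromatic carbon. Among the measured compounds shown here, two measured steps bear on it, each running in the reverse direction: the step of a 2.7-fold higher number from compound 1 to compound 3 (0.44 log units; beyond the scatter) and the step of a 1.8-fold higher number from compound 2 to compound 3 (0.26 log units; within the scatter) both lead from a halogenated phenyl to the 2-methoxyphenyl, and the step of a 1.5-fold higher number from compound 1 to compound 2 (0.18 log units; within the scatter) shows that exchanging one halogen for another there stays within the scatter. Compound 4 is therefore expected to give a lower number than compound 3, and the step of a 2.7-fold lower number from compound 3 to compound 4 (0.44 log units; beyond the scatter) expresses the estimated size of that move. In this assay compound 4 is estimated at 2700 nM, with a range from 1100 nM to 6500 nM.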

Compound 4, half-maximal inhibitory concentration: 2400 nM
Estimate against measurement, compound 4: 1.1-fold (0.05 log units) above; low and high end bracket the measured number.
By their numbers in this assay, from the lowest: compounds 4, 1, 2 and 3 (each within the scatter of the next, the first and the last beyond it).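

In this assay the change from the 2-methoxyphenyl to the 3-bromophenyl, a 3.1-fold lower number from compound 3 to compound 4 (0.49 log units; beyond the scatter), lies beyond the scatter, so a second halogenated phenyl now stands clear of compound 3, while compound 2 remains the halogenated case that does not. Bromo in place of chloro, a 1.1-fold lower number from compound 1 to compound 4 (0.05 log units; within the scatter), and bromo in place of fluoro, a 1.7-fold lower number from compound 2 to compound 4 (0.23 log units; within the scatter), both stay within the scatter, so the three halogens on this aromatic carbon cannot be told apart on this read-out. Nothing available here accounts for these numbers, and no cause can be given for the difference between the halogenated phenyls and the 2-methoxyphenyl.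

The 2-methoxyphenyl and the halogenated phenyls differ both in the group carried and in where the ring carries it, and the compounds shown do not separate these two changes. On these data alone, it also remains open whether a nitrile, a trifluoromethyl, an amine or a carboxylic acid in place of the halogen would give numbers like those of the halogenated compounds or like that of compound 3.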